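Pyridyl-triazole thioethers in HCT-116: hydrazone methoxy to hydroxy

A few compounds are considered here, and "the series" means these few. Any claim that something is new, unique, unknown or untested is made for them only; others in the source may bear on it.

Measured so far, in a functional assay on HCT-116 cells (Homo sapiens) for inhibition, read by MTT assay, with a stated time of 48 h; a higher number here means a weaker inhibitor, a lower number a stronger inhibitor:
compound 1 `Fc1ccc(CSc2nnc(-c3ccncc3)n2-c2ccccc2)c(F)c1` gives 11400 nM
compound 2 `COc1ccc(/C=N/NC(=O)CSc2nnc(-c3ccncc3)n2-c2ccccc2)cc1` gives 19200 nM

For the measured compounds named here, only two compounds carry numbers. Compound 2 sits at the high end of the pair, but compound 1 lies within the usual scatter of it, so the two are not separated by these measurements; neither can be called the stronger or weaker inhibitor on this evidence. Going by the values given here, no pair of measured compounds differs in a single place, so no measured step is available to lean on.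

Compound 3 `O=C(CSc1nnc(-c2ccncc2)n1-c1ccccc1)N/N=C/c1ccc(O)cc1` differs from compound 2 in one place: hydrogen in place of methyl on an oxygen on an aromatic ring; read one bond further out, methoxy becomes hydroxy, 4-methoxyphenyl becomes 4-hydroxyphenyl. Among the compounds with values here, with no comparable step in hand, the change is expected to move this assay little, and the expected step of a 1.3-fold lower number from compound 2 to compound 3 (0.11 log units; within the scatter) is set at no more than the scatter, with a slight lean toward a lower number. On that basis compound 3 is estimated at 15000 nM, with a range from 5000 nM to 45000 nM in this assay.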

Compound 3, half-maximal inhibitory concentration: > 50000 nM
Compound 3 gave a limit, no number (the forecaster's own chance of this, stated with the estimate: 15%); middle value at least 3.3-fold (0.52 log units) from the limit.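

In this assay compound 3 carries a limit of the assay, not a number: the limit of > 50000 nM in this assay, at which 1 of the 3 values shown sits.

Even so, the series now has its first step in a single place, and it can be read in one direction: hydrogen in place of methyl on the oxygen on the aromatic ring, methoxy to hydroxy, gives an at least 2.6-fold higher number from compound 2 to compound 3 (0.41 log units; beyond the scatter). This place on the 4-methoxyphenyl is therefore not indifferent to the change, and the methyl cannot be removed from this oxygen without a loss of inhibition that lies beyond the scatter. On these data alone, the printed size of the step is only a lower bound, so how far the loss goes remains unknown, and this single pair supports no rule for the series as a whole.

The compounds shown leave open whether the loss follows from the free hydroxy itself or from the missing methyl. An amine or a longer ethoxy chain on the same aromatic ring would show whether inhibition stays near that of compound 2 or falls away as it does with compound 3.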